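Solubility notes on a fused bicyclic amine series

The source may report more compounds than this note shows. Statements on the series, on what has been measured and on what is new or still open speak of the compounds shown alone.

Measured so far:
- compound 1, `FC(F)(F)Oc1ccc(-c2nc3cnc(Nc4ccccn4)cc3[nH]2)cc1`: 26000 nM
- compound 2, `FC(F)(F)c1cccc(-c2nc3cnc(Nc4cnccn4)cc3[nH]2)c1`: 155000 nM
- compound 3, `Fc1ccc(Nc2cc3[nH]c(-c4ccc(F)c(F)c4)nc3cn2)nc1`: 42000 nM

Three compounds share the core and have been run in a physicochemical assay for solubility, using the shake flask method, measured as kinetic solubility, with a stated time of 20 h, at pH 2; on this read-out lower numbers stand for lower solubility and higher numbers for higher solubility. Compound 2 gives 155000 nM, the highest of the three numbers; its gaps to compound 3, which gives 42000 nM, and to compound 1, which gives 26000 nM, both lie beyond the scatter of the method, so compound 2 stands clearly at the top of this small set. Among the compounds with values here, no pair among the three differs in one place only, so no single-change step is available from the measured compounds.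

Compound 4, `O=C(O)c1ccc(Nc2cc3[nH]c(-c4cccc(C(F)(F)F)c4)nc3cn2)nc1`, is unmeasured. It differs from compound 2 in one place: 5-carboxypyridin-2-yl in place of pyrazin-2-yl on a nitrogen on an aromatic ring. Within the data shown here, with no matching step in the measured set, the direction rests on judgement alone. A modest downward step a 2.6-fold lower number from compound 2 to compound 4 (0.41 log units; beyond the scatter) is expected, though a result within the scatter or above it cannot be excluded. For compound 4 in this assay the estimate is 60000 nM, with a range from 15000 nM to 250000 nM.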

Compound 4, solubility: < 5000 nM
Compound 4: only a limit was reported (the forecaster's own chance of this, stated with the estimate: 5%); middle value at least 12-fold (1.07 log units) from the limit.
By their numbers in this assay, from the lowest: compounds 1 and 3 (each within the scatter of the next); then compound 2. At a limit, below all of these: compound 4.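

Compound 4 gives < 5000 nM in this assay, which is a limit of the assay and not a number. Within the data shown here, this provides the first single-place comparison and shows that the read-out can move strongly with the group on a nitrogen on an aromatic ring, the shared core and the 3-(trifluoromethyl)phenyl group staying the same: an at least 31-fold lower number from compound 2 to compound 4 (1.49 log units; beyond the scatter), a large change. The size of this step is only a bound, and the true value of compound 4 remains unresolved: the limit of < 5000 nM in this assay, at which 1 of the 4 values shown sits.

The change replaces the ring and introduces the carboxylic acid together, so the compounds shown do not separate the contribution of either. Also open, as far as these compounds go, is how a primary amide or a methyl ester in place of the carboxylic acid would read in this assay.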